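The compounds below may be only part of what the source reports. "The series", "measured", "known", "first", "only" and "open" are said of these compounds alone.

Measured so far:
Compound 1 `N#Cc1ccc(SCCc2ccccc2)cc1C#N`: 124 nM
Compound 2 `CC(C)CCSc1ccc(C#N)c(C#N)c1`: 242 nM
Compound 3 `N#Cc1ccc(SCc2ccc(Cl)cc2)cc1`: 531 nM

These three compounds were tested in an assay on microsomes for inhibition of Amine oxidase [flavin-containing] B (Homo sapiens), read by fluorescence and spectrophotometry, with a stated time of 20 min; on this read-out lower numbers stand for stronger inhibition and higher numbers for weaker inhibition. Compound 1 sits at the low end of the three numbers, but its gap to compound 2 is a 2.0-fold higher number from compound 1 to compound 2 (0.29 log units; within the scatter), so the two cannot be told apart; compound 3, by contrast, gives a number beyond the scatter of compound 1.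

Compound 4 `N#Cc1ccc(SCCc2ccccc2)cc1` has not yet been measured. It differs from compound 1 by a single change: hydrogen in place of cyano on an aromatic carbon. For the measured compounds named here, no measured pair shows exactly this change. Going by the values given here, the one step on record, from compound 1 to compound 2, alters the chain and not the aromatic ring, so it offers no direct guide. Compound 3, which also carries a single cyano group but differs elsewhere as well, gives a higher number than compound 1, and that is the only hint available. A moderately higher number is therefore expected. The estimated step is a 2.4-fold higher number from compound 1 to compound 4 (0.38 log units; beyond the scatter). Compound 4 is expected to give about 300 nM, within a range of 100 nM to 1000 nM.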

Compound 4, half-maximal inhibitory concentration: 1810 nM
Estimate against measurement, compound 4: 6.0-fold (0.78 log units) below; measured number outside the range, above it.
By their numbers in this assay, from the lowest: compounds 1 and 2 (each within the scatter of the next); then compound 3; then compound 4.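

Swapping the cyano group that sits ortho to the other cyano group and meta to the group of 9 heavy atoms for hydrogen gives a 15-fold higher number from compound 1 to compound 4 (1.16 log units; beyond the scatter) in this assay, a large step and well beyond the usual scatter. For the compounds shown here, this is the first single change on record at the aromatic ring, and it shows that this one position weighs far more than the chain change, which gave only a 2.0-fold higher number from compound 1 to compound 2 (0.29 log units; within the scatter) and so could not be told apart from scatter. Keeping both cyano groups therefore goes with the lower number in this pair, where the second cyano group is worth much of the inhibition seen with compound 1.

Still open, from the compounds shown here alone, is whether another group at this position, such as an amine, a carboxylic acid or a trifluoromethyl, would hold the number down, and whether removing this cyano group from compound 2 would cost as much. No measurement at hand explains the size of this step.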